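The source may hold more compounds than are shown below. What is called first, only, known or untested is meant among the compounds shown, and "the series" means these compounds.

Measured compounds:
compound 1 `Nc1scc(CN2CCN(c3ccc(F)cc3Cl)CC2)c1C(=O)c1ccc(Cl)cc1` — -39%
compound 2 `Nc1scc(CN2CCN(c3ccc(Cl)c(C(F)(F)F)c3)CC2)c1C(=O)c1ccc(Cl)cc1` — -47%
compound 3 `Nc1scc(CN2CCN(c3cccc(F)c3)CC2)c1C(=O)c1ccc(Cl)cc1` — -86%

In a functional assay on CHO cells with adenosine receptor A1 (Homo sapiens) as the target, read by cAMP accumulation and immunoassay, with a stated time of 6 min, tested at 1 uM (a higher number here means a weaker effect of the compound at the concentration tested, a lower number a stronger effect), compound 2 gives -47%. Compound 1 lies close by, the step of a number 8 percentage points lower from compound 1 to compound 2 (within the scatter), so the two cannot be told apart. Compound 3 stands well lower, the step of a number 39 percentage points lower from compound 2 to compound 3 (beyond the scatter).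

Compound 4 `Nc1scc(CN2CCN(CCCc3ccc(Cl)cc3)CC2)c1C(=O)c1ccc(Cl)cc1` differs from compound 2 in one place: 3-(4-chlorophenyl)propyl in place of 4-chloro-3-(trifluoromethyl)phenyl on an amine nitrogen in a ring.

All three measured steps swap one aromatic ring for another on the same ring nitrogen. Two of them, a number 47 percentage points lower from compound 1 to compound 3 (beyond the scatter) and a number 39 percentage points lower from compound 2 to compound 3 (beyond the scatter), are large; one, a number 8 percentage points lower from compound 1 to compound 2 (within the scatter), is small. Among the compounds with values here, no measured step replaces the aromatic ring on that nitrogen with a 3-(4-chlorophenyl)propyl chain, so the measured steps show that this position matters but give no direction for this change. The expected step is therefore a number 8 percentage points lower from compound 2 to compound 4 (within the scatter), with a wide range in both directions. For compound 4 the estimate in this assay is -55%, between -90% and -15%.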

Compound 4, a percentage reported as activity, at one concentration (the size of the read-out at that concentration, not a potency): -30%
For compound 4 the middle estimate is 25 percentage points below the measured one; low and high end bracket the measured number.
By their numbers in this assay, from the lowest: compound 3; then compounds 2, 1 and 4 (each within the scatter of the next, the first and the last beyond it).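

Within the data shown here, compound 4 is the first case in which a 3-(4-chlorophenyl)propyl chain, rather than an aromatic ring, sits on the amine nitrogen, and in this assay this change raises the number against two of the ring compounds (a number 17 percentage points higher from compound 2 to compound 4 (beyond the scatter); a number 56 percentage points higher from compound 3 to compound 4 (beyond the scatter)). Against the third ring compound, the change cannot be told from scatter (a number 9 percentage points higher from compound 1 to compound 4 (within the scatter)), so its effect depends on which ring it replaces. Nothing available explains this result.

The compounds shown leave open whether a 2-(4-chlorophenyl)ethyl or 4-(4-chlorophenyl)butyl group would give a lower or higher number than the propyl chain. They also leave open whether a 3-(3-fluorophenyl)propyl group would keep the low number of compound 3 (-86%).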